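A (diethylamino)methyl group added to compound 1

This account rests on a few compounds, and the source may have more. Where it says the series, first, only, none or still open, it means among the compounds named here.

Compound 1 `CCN(CC)Cc1ccc2c(c1O)-c1ccc(cc1O)CCc1ccc(O)c(c1)Oc1ccc(cc1)CC2`: 7590 nM
Compound 2 `CCCCN(CCCC)Cc1ccc2c(c1O)-c1ccc(cc1O)CCc1ccc(O)c(c1)Oc1ccc(cc1)CC2`: > 20000 nM

Among the compounds with values here, in a functional assay on MCF7 cells (Homo sapiens) for antiproliferative activity, read by MTT assay, with a stated time of 48 h (a lower number here means a stronger inhibitor, a higher number a weaker inhibitor), compound 1 gives 7590 nM, the only exact number so far. Compound 2 reads > 20000 nM, which is a limit of the assay and not a number.

Compound 3 `CCN(CC)Cc1cc2cc(c1O)Oc1ccc(cc1)CCc1ccc(CN(CC)CC)c(O)c1-c1ccc(cc1O)CC2` has not been measured yet. Its change from compound 1 is (diethylamino)methyl in place of hydrogen on an aromatic carbon, ortho to a hydroxy group.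

Within the data shown here, only one measured step can guide the expectation: an at least 2.6-fold higher number from compound 1 to compound 2 (0.42 log units; beyond the scatter). That step lies beyond the scatter, but it swaps diethylamino for dibutylamino rather than adding a new group, so it bears only loosely on this change. No step beyond the scatter is therefore expected in this assay, in either direction, though the uncertainty is wide. The estimated change is a 1.0-fold lower number from compound 1 to compound 3 (0.01 log units; within the scatter). For compound 3 the estimated value is 7500 nM, with an expected range from 2500 nM to 20000 nM.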

Compound 3, half-maximal inhibitory concentration: 1050 nM
Compound 3: middle estimate off by 7.1-fold (0.85 log units), on the high side; measured number below the stated range.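

In this assay, placing a (diethylamino)methyl group on this aromatic carbon, ortho to a hydroxy group, gives a 7.2-fold lower number from compound 1 to compound 3 (0.86 log units; beyond the scatter), so compound 3, with a second such group on the shared core, is the stronger inhibitor. Within the data shown here, the earlier pair differed only in the chains on the nitrogen of the existing group, so this is the first sign that a change at this position on the core can lower the number. The data shown do not explain why the number falls.

Going by these compounds, it remains open whether the nitrogen is needed here, which a plain methyl or a hydroxymethyl group at the same position would test. A dibutylamino or morpholine version of the added group would show how much the amine itself matters.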